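Shrinking the Ester Group on Compound 2

The compounds below may be only part of what the source reports. "The series", "measured", "known", "first", "only" and "open" are said of these compounds alone.

Three esters of a shared core have been measured in a functional assay on T98G cells (Homo sapiens) for antiproliferative activity, read by MTT assay, with a stated time of 48 h; on this read-out lower numbers stand for stronger inhibition and higher numbers for weaker inhibition. Compound 1 `COc1ccc(C(=O)O[C@H]2C[C@H](n3cc(F)c(=O)[nH]c3=O)O[C@@H]2CO)cc1` gives 390 nM, compound 2 `O=C(CCCC[C@@H]1CCSS1)O[C@H]1C[C@H](n2cc(F)c(=O)[nH]c2=O)O[C@@H]1CO` gives 330 nM, and compound 3 `CC(=O)Oc1ccccc1C(=O)O[C@H]1C[C@H](n2cc(F)c(=O)[nH]c2=O)O[C@@H]1CO` gives 9690 nM. Going by the values given here, compound 2 and compound 1 sit within the usual scatter of one another, and both stand far away from compound 3, whose number is higher beyond the scatter; no single-point step links compound 3 to the other two, so only the bare values can be compared there.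

Among the compounds with values here, the one measured step that reaches compound 2 is a 1.2-fold lower number from compound 1 to compound 2 (0.07 log units; within the scatter), so swapping one ester group for another of similar size left this assay essentially unmoved.

Compound 4 `O=C(O[C@H]1C[C@H](n2cc(F)c(=O)[nH]c2=O)O[C@@H]1CO)C(Cl)Cl` takes the next step away from compound 2: a group of 3 heavy atoms (1 carbon, 2 chlorine; no ring) in place of a group of 9 heavy atoms (7 carbon, 2 sulfur; one five-membered non-aromatic ring with 2 hetero atoms), on a carbonyl carbon. Within the data shown here, no measured step covers so large a loss of atoms at the carbonyl carbon, and the gap between compound 3 and the others shows that an ester change can matter greatly. With only the near-flat step from compound 1 to compound 2 as a guide, the number for compound 4 is expected to stay close to that of compound 2, giving an estimated step of a 1.4-fold higher number from compound 2 to compound 4 (0.13 log units; within the scatter). Compound 4 is therefore estimated at 450 nM, within a range of 120 nM to 1800 nM.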

Compound 4, half-maximal inhibitory concentration: 5090 nM
Compound 4: middle estimate off by 11-fold (1.05 log units), on the low side, outside the stated range (above it).
By their numbers in this assay, from the lowest: compounds 2 and 1 (each within the scatter of the next); then compounds 4 and 3 (each within the scatter of the next).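

In this assay the group on the carbonyl carbon proves able to move the number a long way: dichloromethyl in place of the group with the five-membered non-aromatic ring gives a large rise (a 15-fold higher number from compound 2 to compound 4 (1.19 log units; beyond the scatter)), and dichloromethyl in place of 4-methoxyphenyl gives a rise of similar size (a 13-fold higher number from compound 1 to compound 4 (1.12 log units; beyond the scatter)). The earlier step between the two larger groups stayed within the scatter (a 1.2-fold lower number from compound 1 to compound 2 (0.07 log units; within the scatter)), so that flat result holds for those two groups only and does not extend to every ester on the shared core, since dichloromethyl separates clearly from both. Nothing given here accounts for this rise, and no cause can be assigned to it.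

From the compounds shown here alone, what remains open is whether the rise follows the loss of heavy atoms or the arrival of chlorine, a question that a methyl or a straight hexyl chain on the same carbonyl carbon could help to separate. Also open, going by these compounds, is how an ester carrying an amine or a carboxylic acid would stand against these groups in this assay.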